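Halogen on the phenol ring beside the hydrazone

A few compounds are considered here, and "the series" means these few. Any claim that something is new, unique, unknown or untested is made for them only; others in the source may bear on it.

Two compounds of this series carry a measured number. Compound 1 `CN(C)CCn1cnnc1-c1cc(Oc2ccc(NC(=O)N/N=C/c3ccc(O)c(Br)c3)cc2F)ccn1` gives 1860 nM in a functional assay on MKN-45 cells (Homo sapiens) for cytotoxicity, read by MTT assay, with a stated time of 72 h; a lower number here means a stronger inhibitor, a higher number a weaker inhibitor. Compound 2 `CN(C)CCn1cnnc1-c1cc(Oc2ccc(NC(=O)N/N=C/c3ccc(O)cc3)cc2F)ccn1` gives 820 nM in this assay. For the measured compounds named here, the single step between them, hydrogen in place of bromo on an aromatic carbon, is a 2.3-fold lower number from compound 1 to compound 2 (0.36 log units; beyond the scatter); compound 2 therefore stands at the lower of the two numbers, with compound 1 as its only neighbour.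

Compound 3 `CN(C)CCn1cnnc1-c1cc(Oc2ccc(NC(=O)N/N=C/c3ccc(O)c(F)c3)cc2F)ccn1` has not been measured. It differs from compound 2 by fluoro in place of hydrogen on an aromatic carbon. Going by the values given here, the only step that bears on this change is the one from compound 1 to compound 2, where a bromo at this same position went with a number that was higher by a 2.3-fold lower number from compound 1 to compound 2 (0.36 log units; beyond the scatter). A fluoro at that carbon is the same kind of change in the opposite direction, with the smallest halogen. A step back toward the number of compound 1 is expected, but a smaller one, likely within the scatter: compound 3 is expected to show a 1.3-fold higher number from compound 2 to compound 3 (0.13 log units; within the scatter) in this assay. The estimate for compound 3 is 1100 nM, within 500 nM to 2400 nM.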

Compound 3, half-maximal inhibitory concentration: 1970 nM
Compound 3: middle estimate off by 1.8-fold (0.25 log units), on the low side, and the stated range covers the measured number.
By their numbers in this assay, from the lowest: compound 2; then compounds 1 and 3 (each within the scatter of the next).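

In this assay, the smallest halogen does not give a smaller step: the change from 4-hydroxyphenyl to 3-fluoro-4-hydroxyphenyl is a 2.4-fold higher number from compound 2 to compound 3 (0.38 log units; beyond the scatter) and so matches the size of the step seen earlier with bromo. Exchanging one halogen for the other on this aromatic carbon, ortho to a hydroxy group, gives a 1.1-fold higher number from compound 1 to compound 3 (0.02 log units; within the scatter) and so does not separate fluoro from bromo, while hydrogen in compound 2 now stands apart from both halogen compounds by steps beyond the scatter. No measurement available on these compounds accounts for the gap between hydrogen and the two halogens at this carbon.

Going by these compounds, whether chloro falls with fluoro and bromo remains open, as does whether a non-halogen group at the same carbon, such as methyl, methoxy or an amine, goes with the same higher number. Also open, on these data alone, is whether the halogen step persists when the hydroxy group is replaced, for instance by methoxy, since both halogens shown sit ortho to that group.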